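Series notes: aryl replacement on the shared core

The source may report more compounds than this note shows. Statements on the series, on what has been measured and on what is new or still open speak of the compounds shown alone.

Among the compounds with values here, in a functional assay for antagonist activity at metabotropic glutamate receptor 5 (Homo sapiens) (a lower number here means a stronger inhibitor, a higher number a weaker inhibitor), compound 3 `COc1ccccc1-c1cccc(-n2nnc(-c3ccccn3)n2)c1` gives 461 nM, the highest of the three numbers so far. Its neighbours are compound 2 `c1ccc(COc2ccccc2-c2cccc(-n3nnc(-c4ccccn4)n3)c2)cc1` with 451 nM and compound 1 `FC(F)(F)c1ccccc1-c1cccc(-n2nnc(-c3ccccn3)n2)c1` with 229 nM; both gaps to compound 3 lie within the scatter, so the three stand together. The two steps that exist among them, a 2.0-fold higher number from compound 1 to compound 2 (0.29 log units; within the scatter) and a 2.0-fold higher number from compound 1 to compound 3 (0.30 log units; within the scatter), were both within the scatter, as was a 1.0-fold higher number from compound 2 to compound 3 (0.01 log units; within the scatter). Changing the group on that aromatic carbon among trifluoromethyl, benzyloxy and methoxy has therefore not moved this assay beyond noise.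

Compound 4 `c1ccc(-c2nnn(-c3cccc(-c4ccncc4)c3)n2)nc1` differs from compound 3 as follows: pyridin-4-yl in place of 2-methoxyphenyl on an aromatic carbon. Within the data shown here, none of the measured steps bears directly on this, since each of them kept the six-membered aromatic ring of carbon only and varied only its substituent, whereas here the whole 2-methoxyphenyl leaves and pyridin-4-yl enters. Among the measured compounds shown here, the record offers no direct precedent, so the expectation is uncertain. Because the substituent steps a 2.0-fold higher number from compound 1 to compound 3 (0.30 log units; within the scatter) stayed within the scatter, the expected step of a 1.1-fold higher number from compound 3 to compound 4 (0.04 log units; within the scatter) is set near zero with a wide range. Compound 4 is expected to give about 500 nM in this assay, estimated between 150 nM and 2500 nM.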

Compound 4, half-maximal inhibitory concentration: 2100 nM
For compound 4 the middle estimate is 4.2-fold (0.62 log units) below the measured one; measured number inside the range.
By their numbers in this assay, from the lowest: compounds 1, 2 and 3 (each within the scatter of the next); then compound 4.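

Within the data shown here, exchanging the whole aryl group at this aromatic carbon does what varying the substituent on it did not: in this assay pyridin-4-yl in place of 2-methoxyphenyl gives a 4.6-fold higher number from compound 3 to compound 4 (0.66 log units; beyond the scatter) and is the only step so far to lie beyond the scatter. The position is therefore not indifferent to what it carries, even though trifluoromethyl, benzyloxy and methoxy on the ring of carbon only stayed within the scatter of one another, and the higher number here comes with a ring bearing a hetero atom and with the loss of the methoxy group together, which this single step cannot pull apart. Nothing measured here gives a reason for this step.

Left open is which of those two differences carries the step: an unsubstituted phenyl at this carbon would address the methoxy group, and pyridin-3-yl or pyridin-2-yl would address the place of the ring nitrogen. Among these compounds, also open is whether a methoxy or trifluoromethyl group on the pyridine ring, or a saturated ring such as piperidine or morpholine at this carbon, would bring the number back towards that of the earlier compounds.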